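This account rests on a few compounds, and the source may have more. Where it says the series, first, only, none or still open, it means among the compounds named here.

Working notes on the series. Compound 2 `O=C(O)C1=Cc2ccccc2OC1(OCc1cc(-c2ccc(F)cc2F)no1)C(F)(F)F` reports only a limit in a functional assay on MCF7 cells (Homo sapiens) for inhibition, read by MTT assay, with a stated time of 24 h; on this read-out lower numbers stand for stronger inhibition and higher numbers for weaker inhibition: compound 2 gives > 150000 nM, a limit of the assay rather than a number. Compound 1 `CCOC(=O)C1=Cc2ccccc2OC1(OCc1cn(CC(=O)Nc2ccc(C)cc2)nn1)C(F)(F)F` likewise sits at a limit in this assay, giving > 150000 nM. Compound 3 `CCOC(=O)C1=Cc2ccccc2OC1(OCc1cn(-c2cccc(C(F)(F)F)c2)nn1)C(F)(F)F` also sits at a limit in this assay, giving > 150000 nM. Compound 2 therefore stands where every measured compound stands, at the limit of > 150000 nM in this assay, at which 3 of the 3 values shown sit, with no number that would place it above or below the others.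

Compound 4 `O=C(O)C1=Cc2ccccc2OC1(OCc1cc(-c2cccc(C(F)(F)F)c2)no1)C(F)(F)F` is not yet measured. It differs from compound 2 as 3-(trifluoromethyl)phenyl in place of 2,4-difluorophenyl on an aromatic carbon. Going by the values given here, the one measured step that bears on this change is a step that the two limits leave unreadable from compound 1 to compound 3, which brings in the same 3-(trifluoromethyl)phenyl group; its size cannot be read, as both ends of it are limits. Among the compounds with values here, no step of readable size exists in this set.

The expectation for compound 4 rests only on this shared limit. Compound 4 is expected to remain at the limit, estimated at 200000 nM with a range from 50000 nM to 1000000 nM. The expected step from compound 2 to compound 4, a step that the limit leaves unreadable from compound 2 to compound 4, is none beyond the scatter, and the likeliest outcome is that this assay again reports only a limit.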

Compound 4, half-maximal inhibitory concentration: > 150000 nM
Compound 4: a limit, no number (the forecaster's own chance of this, stated with the estimate: 85%); the middle value does not contradict the limit.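

In this assay, going by these compounds alone, compound 4 gives > 150000 nM as a limit and not a number, so no step of readable size can be taken from compound 2 to compound 4. The series stands at one place: the limit of > 150000 nM in this assay, at which 4 of the 4 values shown sit.

The compounds shown leave open whether any change on the shared core gives a value inside the range of the assay.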